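Carbamate in place of the dimethylcarbamoyl amide

The source may report more compounds than this note shows. Statements on the series, on what has been measured and on what is new or still open speak of the compounds shown alone.

Compound 1 `CCCC[S+]([O-])c1sc2nc(-c3nccs3)cc(-c3ccc(C(=O)N(C)C)cc3)c2c1N` gives 5.9 nM in an assay for inhibition of 15-hydroxyprostaglandin dehydrogenase [NAD(+)] (Homo sapiens), read by fluorescence, with a stated time of 15 min, in the presence of a further agent that is not named here (on this read-out lower numbers stand for stronger inhibition and higher numbers for weaker inhibition), the lowest of the two numbers in hand. Among the measured compounds shown here, compound 2 `CCCCS(=O)(=O)c1sc2nc(-c3nccs3)cc(-c3cnc(C)n3C)c2c1N` gives 32 nM in this assay; the gap to compound 1 lies beyond the scatter, but the two differ in more than one place, so no single step is defined. Compound 3 `CCCC[S+]([O-])c1sc2nc(-c3nccs3)cc(-c3ccc(COC(=O)NCC)cc3)c2c1N` carries ((ethylcarbamoyl)oxy)methyl in place of dimethylcarbamoyl on an aromatic carbon. For the measured compounds named here, no measured step covers this exchange; a step of modest size is expected, more likely toward a higher number, though it may stay within the scatter. Compound 3 is expected to give about 12 nM in this assay, with a range of 3.5 nM to 45 nM. This corresponds to an estimated step of a 2.0-fold higher number from compound 1 to compound 3 (0.31 log units; beyond the scatter).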

Compound 3, half-maximal inhibitory concentration: 3.4 nM
The estimate for compound 3 lay 3.5-fold (0.55 log units) above the measured number; measured number outside the range, below it.
By their numbers in this assay, from the lowest: compounds 3 and 1 (each within the scatter of the next); then compound 2.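

In this assay, ((ethylcarbamoyl)oxy)methyl in place of dimethylcarbamoyl on this aromatic carbon, para to a large group, gives a 1.7-fold lower number from compound 1 to compound 3 (0.24 log units; within the scatter). The position therefore holds the group with more heavy atoms and a hydrogen-bond donor, with no difference beyond the scatter. No measurement here bears on the reason for this result.

Still open, from the compounds shown here alone, is how far this position extends: whether a longer chain, such as butyl in place of ethyl on the carbamate nitrogen, keeps the number in this range. A carboxylic acid or a primary amine on the same carbon also remains untested by the compounds shown.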